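The source may hold more compounds than are shown below. What is called first, only, known or untested is meant among the compounds shown, and "the series" means these compounds.

Measured compounds:
Compound 1, `Cc1c(C(=O)Nc2ccc(-c3ccccc3)cc2)nc2ccccc2c1O`, gives 1.68% in a functional assay on Hep 3B2 cells (Homo sapiens) for antiproliferative activity, read by MTT assay, with a stated time of 24 h, tested at 0.05 ug/mL; a higher number here means a stronger effect of the compound at the concentration tested, a lower number a weaker effect.
Compound 2, `COc1ccc2nc(C(=O)Nc3ccc(-c4ccccc4)cc3)c(C)c(C(=O)O)c2c1`, gives 0.65% in this assay.

Two amides sharing one core have been tested so far. Compound 2 stands alongside compound 1 in this assay: the gap between their two numbers is within the scatter, so neither can be set apart from the other, and both read-outs sit near the floor of the assay. The shared core, an amide to a biphenyl amine, shows no measurable inhibition in either case.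

Compound 3, `Cc1c(C(=O)Nc2ccc(-c3ccccc3)cc2)nc2ccccc2c1C(=O)O`, has not yet been measured. It differs from compound 2 in one place: hydrogen in place of methoxy on an aromatic carbon. Among the compounds with values here, no pair of measured compounds that differ in a single place is available to size such a change. Since compound 1 and compound 2 both give numbers near zero, and the change to compound 3 touches only the methoxy, the step from compound 2 to compound 3 in this assay is expected to be none beyond the scatter, in no particular direction. Compound 3 is therefore estimated to give 1.5%, with a range from -8% to 12%, and the implied change is a number 0.9 percentage points higher from compound 2 to compound 3 (within the scatter).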

Compound 3, a percentage reported as inhibition, at one concentration (the size of the read-out at that concentration, not a potency): -0.12%
Compound 3: middle estimate off by 1.6 percentage points, on the high side; the range from low to high includes it.
By their numbers in this assay, from the lowest: compounds 3, 2 and 1 (each within the scatter of the next).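

Hydrogen in place of methoxy on an aromatic carbon gives a number 0.8 percentage points lower from compound 2 to compound 3 (within the scatter) in this assay, the first step at this position that can be read, and the two groups cannot be told apart there. Carboxy in place of hydroxy on an aromatic carbon gives a number 1.8 percentage points lower from compound 1 to compound 3 (within the scatter), so this second change cannot be told apart from no change in this read-out either. Within the data shown here, all three compounds sit near the floor of the assay, so these steps show only that neither change brings out inhibition beyond the scatter at the single concentration tested, and they say nothing about how either change would act on a compound with a clear effect. No measurement shown here offers a cause for these results.

As far as these compounds go, it remains open whether an amine or a longer alkoxy chain on that aromatic carbon, or an ester in place of the carboxy group, would move the read-out clear of the scatter. From the compounds shown here alone, a single-concentration read-out also gives no potency, so how these compounds would behave at higher concentrations stays unknown.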